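The source may report more compounds than this note shows. Statements on the series, on what has been measured and on what is new or still open speak of the compounds shown alone.

Values in a functional assay on the whole organism for cytotoxicity, with Homo sapiens as the target (a higher number here means a weaker inhibitor of growth, a lower number a stronger inhibitor of growth), so far
- compound 1 `CCCCCCn1c(=O)oc2ccc(NCc3cc(O)ccc3O)cc2c1=O` gives 1700 nM
- compound 2 `Oc1ccc(O)c(CNc2ccc(O)c(/C=C\CCc3ccccc3)c2)c1` gives 21900 nM

Compound 2 has the higher number of the two, which makes it the weaker inhibitor of growth, and its gap to compound 1 lies beyond the usual scatter. Compound 3 `Oc1ccc(O)c(CNc2ccc(O)c(/C=C/CCc3ccccc3)c2)c1` has the same atoms and bonds as compound 2 and differs only in configuration as drawn (the two compounds have the same atoms and bonds and differ only in configuration as drawn: 1 of 1 stereo elements differ; a double bond is drawn Z in compound 2 and E in compound 3). A double bond is drawn Z in compound 2 and E in compound 3. Among the measured compounds shown here, no measured pair here shows what such a switch does, so no step beyond the scatter is expected in this assay, and neither direction can be favoured. The expectation therefore stays close to compound 2 (21900 nM). The expected change is small (a 1.5-fold lower number from compound 2 to compound 3 (0.16 log units; within the scatter)). The estimate for compound 3 is 15000 nM (expected range 5000 nM to 45000 nM).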

Compound 3, concentration for 50% growth inhibition: 20400 nM
Compound 3: middle estimate off by 1.4-fold (0.13 log units), on the low side; the measured number falls inside the stated range.
By their numbers in this assay, from the lowest: compound 1; then compounds 3 and 2 (each within the scatter of the next).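

Among the compounds shown here, this is the first pair in the set that differs in one place only, so it gives the first direct reading of a single structural change in this assay. Turning the double bond of the side chain from Z to E gives (a 1.1-fold lower number from compound 2 to compound 3 (0.03 log units; within the scatter)), so at this position the drawn configuration has no effect that can be told apart from the scatter. The comparison isolates that one feature, because nothing else separates the two structures: the fact that compounds 2 and 3 differ only in the configuration as drawn.

The compounds shown leave open what a saturated chain in place of the double bond, a longer chain or an amine on that chain would do in this assay. Compound 1 differs from both compounds in more than one place, so the source of its separate value cannot be traced to any single feature.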